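The compounds below may be only part of what the source reports. "The series", "measured", "known", "first", "only" and "open" are said of these compounds alone.

Measured so far in a functional assay on SH-SY5Y cells (Homo sapiens) for inhibition, read by sulforhodamine B assay; on this read-out lower numbers stand for stronger inhibition and higher numbers for weaker inhibition

Compound 1 `COC(=O)CC/C(C)=C/Cc1c(OC)c(C)c2c(c1OCC#CCN1CCN(C(c3ccc(F)cc3)c3ccc(F)cc3)CC1)C(=O)OC2` gives 25800 nM
Compound 2 `COC(=O)CC/C(C)=C/Cc1c(OC)c(C)c2c(c1OCC#CCN1CCN(c3ccc(O)cc3)CC1)C(=O)OC2` gives 46100 nM
Compound 3 `COC(=O)CC/C(C)=C/Cc1c(OC)c(C)c2c(c1OCC#CCN1CCN(C(c3ccccc3)c3ccc(Cl)cc3)CC1)C(=O)OC2` gives 9900 nM

In this assay compound 2 gives 46100 nM and stands within the usual scatter of compound 1 at 25800 nM on this small scale. Compound 3 at 9900 nM shows a lower number than compound 2, beyond the scatter, and so stronger inhibition.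

Compound 4 `COC(=O)CC/C(C)=C/Cc1c(OC)c(C)c2c(c1OCC#CCN1CCN(c3ccccc3OC)CC1)C(=O)OC2` has not yet been measured. It carries 2-methoxyphenyl in place of 4-hydroxyphenyl on an amine nitrogen in a ring and is otherwise the same as compound 2.

Among the measured compounds shown here, no two measured compounds differ in one place only, so the data hold no direct precedent for this change. Compound 3 at 9900 nM lacks the 4-hydroxyphenyl and has the lower number, but compound 1 at 25800 nM lacks it too and goes against any such trend, since it stays within the scatter of compound 2. The guide is therefore weak, and only a modest move towards stronger inhibition is expected. The estimated change is a 1.8-fold lower number from compound 2 to compound 4 (0.25 log units; within the scatter) in that direction. Compound 4 is expected at about 26000 nM with an estimated range from 10000 nM to 60000 nM in this measurement.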

Compound 4, half-maximal inhibitory concentration: 43600 nM
Beside the measured number, compound 4's estimate is 1.7-fold (0.22 log units) below it, and the stated range covers the measured number.
By their numbers in this assay, from the lowest: compound 3; then compounds 1, 4 and 2 (each within the scatter of the next).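

In this assay, among the compounds shown here, the exchange of 4-hydroxyphenyl for 2-methoxyphenyl on an amine nitrogen in a ring gives the first comparison in this set between two compounds that differ in one place only. The step is a 1.1-fold lower number from compound 2 to compound 4 (0.02 log units; within the scatter), so this assay does not separate the two groups at this position. 2-Methoxyphenyl has no hydrogen-bond donor where 4-hydroxyphenyl has one, and it carries one more heavy atom, yet neither difference leaves a mark on the number beyond the usual scatter in this single pair. Nothing measured here speaks to the reason for this outcome.

This one step changes both the oxygen-bearing group and its place on the phenyl ring, so the compounds shown cannot say what either change does alone, and 4-methoxyphenyl or 2-hydroxyphenyl on the same nitrogen would be needed to pull the two apart. They also leave open whether this flat result holds for other groups at this position, such as a plain phenyl, a pyridine or a carboxylic acid on the phenyl ring.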